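Oxazolyl for tert-butyl on the carbamate aryl ring

The source may hold more compounds than are shown below. What is called first, only, known or untested is meant among the compounds shown, and "the series" means these compounds.

Two compounds of the shared core have numbers in an assay on HEK293 cells for inhibition of N-acylethanolamine-hydrolyzing acid amidase (Homo sapiens), read by fluorescence, with stated times of 10 min and 50 min; on this read-out lower numbers stand for stronger inhibition and higher numbers for weaker inhibition. Compound 1 `CC(C)(C)c1ccc(COC(=O)N[C@H]2CNC2=O)cc1` gives 310 nM, and compound 2 `O=C(N[C@H]1CNC1=O)OCc1ccc2c(c1)CCC2` gives 130 nM. Compound 1 stands highest of the two; its nearest neighbour is compound 2, whose number is lower by a gap that lies beyond the usual scatter. Going by the values given here, no single-point step between measured compounds is available, so the two values can only be set side by side.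

Compound 3 `O=C(N[C@H]1CNC1=O)OCc1ccc(-c2cocn2)cc1` is the next member. Relative to compound 1 the change is 1,3-oxazol-4-yl in place of tert-butyl on an aromatic carbon, para to a large group. Nothing measured in this series speaks directly to this exchange, so the expectation rests on the range the two known values span. A step of modest size towards a lower number is expected, a 1.6-fold lower number from compound 1 to compound 3 (0.19 log units; within the scatter), though one within the scatter cannot be excluded. Compound 3 is therefore estimated at 200 nM in this assay, with a range from 60 nM to 700 nM.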

Compound 3, half-maximal inhibitory concentration: 1880 nM
The estimate for compound 3 lay 9.4-fold (0.97 log units) below the measured number, and the stated range ends below it.
By their numbers in this assay, from the lowest: compound 2; then compound 1; then compound 3.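

In this assay, putting 1,3-oxazol-4-yl in place of tert-butyl on an aromatic carbon, para to a large group, gives a 6.1-fold higher number from compound 1 to compound 3 (0.78 log units; beyond the scatter). Going by these compounds alone, this is the first single-place step and it lies beyond the scatter, so the substituent at this position matters for inhibition, and here the exchange runs towards weaker inhibition. The step does not separate the possible contributors, as the entering group differs from tert-butyl in having one five-membered aromatic ring, 2 hetero atoms and 2 hydrogen-bond acceptors, and no measurement at hand accounts for the loss.

Open, going by these compounds, is whether a phenyl ring at the same aromatic carbon, which would keep an aromatic ring without hetero atoms, would follow compound 1 or compound 3. Also open, on these data alone, is whether the other oxazole attachments, or a cyclopentyl ring that keeps a carbon-only group of similar size, would stay close to compound 1, and whether any replacement of tert-butyl at this position can reach a lower number.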